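This account rests on a few compounds, and the source may have more. Where it says the series, first, only, none or still open, it means among the compounds named here.

Measured compounds:

Compound 1, `O=C1/C(=C/c2ccc(Br)cc2)Cc2ccccc21`: in a functional assay on MOLT-4 cells (Homo sapiens) for inhibition (a lower number here means a stronger inhibitor, a higher number a weaker inhibitor), compound 1 gives > 500000 nM, which is a limit of the assay and not a number.
Compound 2, `Cc1ccc(/C=C2\Cc3ccccc3C2=O)cc1`: in this assay compound 2 gives > 500000 nM, again a limit and not a number.
Compound 3, `O=C1/C(=C/c2ccc(Br)cc2)CCc2ccccc21`: in this assay compound 3 gives > 500000 nM, once more a limit and not a number.

Compound 2 differs from compound 1 in a single place: methyl in place of bromo on an aromatic carbon. The step that the two limits leave unreadable from compound 1 to compound 2 cannot be sized because of the limit of > 500000 nM in this assay, at which 3 of the 3 values shown sit. Compound 3 carries a different core from compound 1; the difference between the two cores is not broken down here.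

Compound 4, `Cc1ccc(/C=C2\CCc3ccccc3C2=O)cc1`, is not yet measured. It stands to compound 3 exactly as compound 2 stands to compound 1: methyl in place of bromo on an aromatic carbon. The two "place" descriptions agree word for word, so this is the same change made on the other core.

For compound 4 the expected step is a step that the limit leaves unreadable from compound 3 to compound 4. This expectation rests on compound 3, which gives only the limit > 500000 nM. It also rests on the fact that the matching step that the two limits leave unreadable from compound 1 to compound 2 could not be read, so nothing suggests that swapping bromo for methyl moves a compound off the limit. Compound 4 is therefore expected at 700000 nM, most likely between 300000 nM and 3000000 nM, and most likely reported only as a limit.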

Compound 4, half-maximal inhibitory concentration: > 500000 nM
Compound 4 was reported as a limit; the forecaster's own chance of this, stated with the estimate: 85%; the middle value is on the limit's open side.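

In this assay compound 4 gives > 500000 nM, which is a limit of the assay and not a number. The change from bromo to methyl between compound 3 and compound 4 therefore cannot be sized, because both compounds sit at the same limit: the limit of > 500000 nM in this assay, at which 4 of the 4 values shown sit.

The compounds shown leave open how strongly any of the four inhibits, and whether methyl and bromo differ at all on either core.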